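This account rests on a few compounds, and the source may have more. Where it says the series, first, only, none or still open, it means among the compounds named here.

Series notes on the shared core of compound 1 `CC1(C)Oc2ccc(C#N)cc2[C@@H](/N=C(\NC#N)Nc2ccc(N)cc2)[C@@H]1O` and three variations of the group attached to the cyanoguanidine.

In a functional assay (aorta) with Rattus norvegicus as the target (a higher number here means a weaker inhibitor, a lower number a stronger inhibitor), compound 1 gives 3500 nM. Among the three measured compounds this is the second highest number: compound 2 `C/N=C(\NC#N)N[C@@H]1c2cc(C#N)ccc2OC(C)(C)[C@H]1O` gives 200 nM in this assay, and compound 3 `CCC(C)(C)/N=C(\NC#N)N[C@@H]1c2cc(C#N)ccc2OC(C)(C)[C@H]1O` gives 29800 nM. Both gaps to compound 1 lie beyond the scatter, so compound 2 is the strongest inhibitor of the three and compound 3 the weakest.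

Among the measured compounds shown here, the only step measured within one place is a 150-fold higher number from compound 2 to compound 3 (2.17 log units; beyond the scatter), a change from a small to a bulky alkyl group on the double-bonded nitrogen.

Compound 4 `CSc1cccc(N/C(=N/[C@@H]2c3cc(C#N)ccc3OC(C)(C)[C@H]2O)NC#N)c1` differs from compound 1 as follows: 3-(methylsulfanyl)phenyl in place of 4-aminophenyl on an amine nitrogen. Here the aryl group itself is exchanged, while the attachment to the amine nitrogen is kept. For the measured compounds named here, no measured step bears on the exchange of one aryl group for another; the step from compound 2 to compound 3 concerns a different position and a different kind of group, so it gives no direction for this change. The expectation is therefore a step of a 1.2-fold lower number from compound 1 to compound 4 (0.07 log units; within the scatter), small and without a clear direction. Compound 4 is estimated at 3000 nM in this assay, expected to fall between 500 nM and 15000 nM.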

Compound 4, half-maximal inhibitory concentration: 1400 nM
For compound 4 the middle estimate is 2.1-fold (0.33 log units) above the measured one; measured number inside the range.
By their numbers in this assay, from the lowest: compound 2; then compound 4; then compound 1; then compound 3.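

In this assay, among the compounds shown here, the exchange on the amine nitrogen gives a 2.5-fold lower number from compound 1 to compound 4 (0.40 log units; beyond the scatter), the first measured step between two aryl groups at this place. It is modest but beyond the scatter, so the number here does respond to the aryl group while the attachment to the amine nitrogen is kept, which a 150-fold higher number from compound 2 to compound 3 (2.17 log units; beyond the scatter) could not show, as that step concerns alkyl groups on a double-bonded nitrogen. The step is a single reading of a bundled change, since the leaving 4-aminophenyl has 1 hydrogen-bond donor and a nitrogen, while the entering 3-(methylsulfanyl)phenyl has 0 hydrogen-bond donors and a sulfur; nothing given here bears on what lies behind the lower number.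

The compounds shown leave open whether the lower number comes from losing the amino group, from gaining the methylsulfanyl group, or from both, and plain phenyl on the same amine nitrogen would help to separate these. Also open, as far as these compounds go, is how far the trend extends to other groups on that phenyl ring, such as a methoxy group or a carboxylic acid.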